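Second chloro on the core of compound 1: expected growth inhibition

The source may hold more compounds than are shown below. What is called first, only, known or untested is meant among the compounds shown, and "the series" means these compounds.

Compound 1 `ClCc1ccccc1Cn1cnc2ncnc(Cl)c21` gives 3890 nM in a functional assay on HT-29 cells (Homo sapiens) for cytotoxicity, read by sulforhodamine B assay, with a stated time of 48 h; a lower number here means a stronger inhibitor of growth, a higher number a weaker inhibitor of growth.
Compound 2 `ClCc1cccc(Cn2cnc3nc(Cl)nc(Cl)c32)c1` gives 340 nM in this assay.

Compound 1 stands at the highest of the two numbers; the gap to compound 2 is beyond the scatter. Among the measured compounds shown here, compound 2 differs from compound 1 in more than one place, so no single step is drawn between them. Compound 3 `ClCc1ccccc1Cn1cnc2nc(Cl)nc(Cl)c21` differs from compound 1 by chloro in place of hydrogen on an aromatic carbon. For the measured compounds named here, no measured pair isolates this change. In this assay the step from compound 1 to compound 3 is expected to be a fall beyond the scatter, a 4.9-fold lower number from compound 1 to compound 3 (0.69 log units; beyond the scatter), since compound 2, which carries the same second chloro, gives 340 nM. Compound 3 is estimated at 800 nM, within 250 nM to 2500 nM.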

Compound 3, concentration for 50% growth inhibition: 400 nM
Compound 3: the middle estimate sits 2.0-fold (0.30 log units) above what was measured; measured number inside the range.
By their numbers in this assay, from the lowest: compounds 2 and 3 (each within the scatter of the next); then compound 1.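

In this assay, chloro in place of hydrogen on the aromatic carbon between two ring nitrogen atoms now stands as a single change, with a 9.7-fold lower number from compound 1 to compound 3 (0.99 log units; beyond the scatter) and the rest of the structure unchanged. The earlier gap between compound 1 and compound 2 involved more than one place, so it could not be assigned to this position alone. No measurement shown accounts for the size of this step.

Open, from the compounds shown here alone, is whether an amine or a methoxy group on this same carbon would give a step of similar size.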